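The source may report more compounds than this note shows. Statements on the series, on what has been measured and on what is new or still open speak of the compounds shown alone.

Within the data shown here, compound 2 `Cc1ccc(-c2cn(/N=C/c3cc4cc(C)ccc4nc3Cl)c(N)n2)cc1` gives 22300 nM in a functional assay on MDA-MB-231 cells (Homo sapiens) for cytotoxicity, read by MTT assay, with a stated time of 48 h (a higher number here means a weaker inhibitor, a lower number a stronger inhibitor), the only number yet obtained. Compound 1 `Cc1ccc(-c2cn(/N=C/c3cc4ccccc4nc3Cl)c(N)n2)cc1` gives > 50000 nM in this assay, which is a limit of the assay and not a number. Among the measured compounds shown here, the sole measured step, an at least 2.2-fold lower number from compound 1 to compound 2 (0.35 log units; beyond the scatter), rests on that limit, (the limit of > 50000 nM in this assay, at which 1 of the 2 values shown sits). Compound 3 `Cc1ccc2nc(Cl)c(/C=N/n3cc(-c4cccc5ccccc45)nc3N)cc2c1` differs from compound 2 by naphthalen-1-yl in place of 4-methylphenyl on an aromatic carbon. For the measured compounds named here, no measured step touches that part of the structure, so no change beyond the scatter is expected in this assay. Compound 3 is therefore estimated at 20000 nM, within 7000 nM to 50000 nM. The expected step is a 1.1-fold lower number from compound 2 to compound 3 (0.05 log units; within the scatter).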

Compound 3, half-maximal inhibitory concentration: > 50000 nM
Compound 3: no number, only a limit (the forecaster's own chance of this, stated with the estimate: 25%); at least 2.5-fold (0.39 log units) between middle value and limit.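

Among these compounds, this aromatic carbon of the five-membered ring, which no earlier step touched, proves sensitive to the change of aryl group: naphthalen-1-yl in place of 4-methylphenyl gives an at least 2.2-fold higher number from compound 2 to compound 3 (0.35 log units; beyond the scatter). The added methyl of compound 2 therefore does not keep the number measurable with this larger group. Compound 3 stands at a limit of the assay, not a number, so the step gives only a direction and a minimum size: the limit of > 50000 nM in this assay, at which 2 of the 3 values shown sit.

Open, going by these compounds, is how a phenyl bearing an amine or a carboxylic acid in place of the methyl would read here. Also open, on these data alone, is how far compound 3 lies from its limit.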